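This account rests on a few compounds, and the source may have more. Where it says the series, first, only, none or still open, it means among the compounds named here.

Working notes on the carbonyl-linked aryl group of this small series.

Compound 1 `COc1cc(-c2nnc3n2NC(c2ccco2)C(C(=O)c2ccccc2C)S3)cc(OC)c1OC` carries 2-methylphenyl on the carbonyl carbon; in a functional assay on PC-3 cells (Homo sapiens) for cytotoxicity, read by MTT assay, with a stated time of 48 h (a higher number here means a weaker inhibitor, a lower number a stronger inhibitor), compound 1 gives 88400 nM. Compound 2 `COc1cc(-c2nnc3n2NC(c2ccco2)C(C(=O)c2ccc(F)cc2)S3)cc(OC)c1OC` gives 27700 nM in this assay, the step being a 3.2-fold lower number from compound 1 to compound 2 (0.50 log units; beyond the scatter). For compound 3 `COc1cc(-c2nnc3n2NC(c2ccco2)C(C(=O)c2cccc4ccccc24)S3)cc(OC)c1OC` the this assay reports only a limit, > 100000 nM. Compound 3 thus has no number of its own; against compound 2 it reads an at least 3.6-fold higher number from compound 2 to compound 3 (0.55 log units; beyond the scatter), against compound 1 an at least 1.1-fold higher number from compound 1 to compound 3 (0.05 log units; that floor lies within the scatter).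

Compound 4 `COc1cc(-c2nnc3n2NC(c2ccco2)C(C(=O)c2ccc(O)cc2)S3)cc(OC)c1OC` differs from compound 3 by 4-hydroxyphenyl in place of naphthalen-1-yl on a carbonyl carbon. The step that bears on this exchange is the one from 4-fluorophenyl to naphthalen-1-yl, which raised the number beyond the scatter; returning toward a single six-membered ring is therefore expected to lower it by about an at least 2.5-fold lower number from compound 3 to compound 4 (0.39 log units; beyond the scatter). Compound 4 is estimated at 40000 nM in this assay, with a range from 12000 nM to 130000 nM.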

Compound 4, half-maximal inhibitory concentration: 38300 nM
The estimate for compound 4 lay 1.0-fold (0.02 log units) above the measured number, within the range that was stated.
By their numbers in this assay, from the lowest: compounds 2 and 4 (each within the scatter of the next); then compound 1. At a limit, above all of these: compound 3.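

Hydroxy in place of fluoro gives a 1.4-fold higher number from compound 2 to compound 4 (0.14 log units; within the scatter) in this assay, so the single new value shows that this exchange on the phenyl ring leaves the reading unresolved. 4-Hydroxyphenyl also reads lower than the other two aryl groups, with a 2.3-fold lower number from compound 1 to compound 4 (0.36 log units; beyond the scatter) and an at least 2.6-fold lower number from compound 3 to compound 4 (0.41 log units; beyond the scatter), which makes the pair of 4-substituted phenyl groups the lower end of this small series. Compound 3 remains a limit of the assay, not a number: the limit of > 100000 nM in this assay, at which 1 of the 4 values shown sits.

On these data alone, whether an amine or a carboxylic acid in place of the hydroxy would read alike stays open.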